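The source may hold more compounds than are shown below. What is called first, only, known or untested is meant among the compounds shown, and "the series" means these compounds.

Working notes on the sulfonyl series. In an assay on isolated protein for displacement of a labelled ligand from metabotropic glutamate receptor 5 (Homo sapiens), with a stated time of 60 min, tested at 1 uM (a higher number here means more inhibition at the concentration tested (going by the name of the read-out), a lower number less inhibition), compound 1 `CC1CCN(c2c(S(=O)(=O)c3ccc(Cl)cc3)cnc3cc(Cl)ccc23)CC1` gives 91%, compound 2 `CC1CCN(c2c(S(=O)(=O)c3cc(Cl)cc(Cl)c3)cnc3cc(Cl)ccc23)CC1` gives 93% and compound 3 `Cc1ccc(S(=O)(=O)c2cnc3cc(Cl)ccc3c2N2CCC(C)CC2)cc1C` gives 86%. Compound 3 sits at the lower end of the three numbers, yet a number 5 percentage points lower from compound 1 to compound 3 (within the scatter) and a number 7 percentage points lower from compound 2 to compound 3 (within the scatter), so all three read as one level in this assay. Compound 4 `Cc1ccc(S(=O)(=O)c2cnc3cc(Cl)ccc3c2N2CCC(C)CC2)cc1F` differs from compound 3 by fluoro in place of methyl on an aromatic carbon. The two measured steps that bear on this are the earlier exchanges of the aryl group on the sulfonyl sulfur, both of which stayed within the scatter, so no step beyond the scatter is expected in this assay from this change. Compound 4 is therefore expected to give 87%, in the range 77% to 95%, an expected a number 1 percentage points higher from compound 3 to compound 4 (within the scatter).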

Compound 4, a percentage reported as inhibition, at one concentration (the size of the read-out at that concentration, not a potency): 85%
For compound 4 the middle estimate is 2 percentage points above the measured one; measured number inside the range.
By their numbers in this assay, from the lowest: compounds 4, 3, 1 and 2 (each within the scatter of the next).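

In this assay, replacing a single substituent on the sulfonyl aryl group, rather than the whole group, gives a number 1 percentage points lower from compound 3 to compound 4 (within the scatter), so this aromatic carbon carries fluoro in place of methyl with no step beyond the scatter. The 3-fluoro-4-methylphenyl group also stays level with the other aryl groups, with a number 8 percentage points lower from compound 2 to compound 4 (within the scatter) and a number 6 percentage points lower from compound 1 to compound 4 (within the scatter), so all four compounds read as one level. Nothing available explains this outcome. The read-out at one concentration is not a potency, so any differences in potency among the four remain unresolved. As far as these compounds go, whether an amine or a carboxylic acid on this carbon would hold the same level also remains open.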